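Oxadiazole Replaces Thioester on the Piperidine Carbonyl

The source may hold more compounds than are shown below. What is called first, only, known or untested is meant among the compounds shown, and "the series" means these compounds.

Among the compounds with values here, in a functional assay on isolated protein for inhibition of Glucose-dependent insulinotropic receptor (Homo sapiens), read by HTRF and cAMP accumulation (on this read-out higher numbers stand for an effect only at larger amounts of compound and lower numbers for an effect already at smaller amounts), compound 2 `Cc1nc(S(C)(=O)=O)ccc1Oc1ncnc(OC2CCN(C(=O)SC3(C)CC3)CC2)c1F` gives 13.2 nM, the lower of the two numbers known, though the gap to compound 1 lies within the scatter. Compound 1 `Cc1nc(S(C)(=O)=O)ccc1Oc1ncnc(OC2CCN(C(=O)OC(C)(C)CF)CC2)c1F` gives 19.9 nM in this assay, and a 1.5-fold lower number from compound 1 to compound 2 (0.18 log units; within the scatter). Compound 3 `Cc1nc(S(C)(=O)=O)ccc1Oc1ncnc(OC2CCN(C(=O)c3noc(C(C)C)n3)CC2)c1F` carries a further change at the same place: a group of 8 heavy atoms (5 carbon, 2 nitrogen, 1 oxygen; one five-membered aromatic ring with 3 hetero atoms) in place of a group of 5 heavy atoms (4 carbon, 1 sulfur; one three-membered non-aromatic ring of carbon only), on a carbonyl carbon. Within the data shown here, only the step from compound 1 to compound 2 bears on this carbonyl carbon, and it stayed within the scatter, so no movement beyond the scatter is expected here, in either direction. Compound 3 is therefore estimated at 15 nM, between 5 nM and 50 nM, which means a 1.1-fold higher number from compound 2 to compound 3 (0.06 log units; within the scatter).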

Compound 3, half-maximal effective concentration: 21.2 nM
Compound 3: the middle estimate sits 1.4-fold (0.15 log units) below what was measured; measured number inside the range.
By their numbers in this assay, from the lowest: compounds 2, 1 and 3 (each within the scatter of the next).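

In this assay, within the data shown here, the carbonyl carbon accepts the 5-isopropyl-1,2,4-oxadiazol-3-yl group, an aromatic ring bonded directly to it, without leaving the scatter of the earlier compounds, whether compared with the thioester group (a 1.6-fold higher number from compound 2 to compound 3 (0.21 log units; within the scatter)) or with the fluorinated carbamate group (a 1.1-fold higher number from compound 1 to compound 3 (0.03 log units; within the scatter)). So far, three quite different groups at this place read alike. No evidence is available that bears on this result. Still open, on these data alone, is whether an amine or a longer alkyl chain on this carbonyl carbon would move the number beyond the scatter.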